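The source may hold more compounds than are shown below. What is called first, only, known or untested is meant among the compounds shown, and "the series" means these compounds.

Measured so far in an ADME assay on HepG2 cells (Homo sapiens) for inhibition, with a stated time of 48 h; on this read-out lower numbers stand for an effect already at smaller amounts and higher numbers for an effect only at larger amounts of compound:
- compound 1, `CC(C(=O)N1C[C@H]2CCC[C@H]2C1)N1CCN(S(=O)(=O)c2ccc(C(C)(C)C)cc2)CC1`: compound 1 reaches only the limit > 40000 nM.
- compound 2, `CC(C(=O)N1CCc2ccccc2C1)N1CCN(S(=O)(=O)c2ccc(C(C)(C)C)cc2)CC1`: compound 2 gives 29000 nM.

Compound 2 carries the only number shown in this assay; the other value is a limit (the limit of > 40000 nM in this assay, at which 1 of the 2 values shown sits), so compound 2 stands alone as the single measured point. Among the measured compounds shown here, the one measured step, an at least 1.3-fold lower number from compound 1 to compound 2 (0.13 log units; that floor lies within the scatter), exchanges the group on the carbonyl carbon, and because one end of that step is the limit (the limit of > 40000 nM in this assay, at which 1 of the 2 values shown sits), its true size stays open.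

Compound 3, `CC(C(=O)N1CCc2ncccc2C1)N1CCN(S(=O)(=O)c2ccc(C(C)(C)C)cc2)CC1`, differs from compound 2 in a group of 10 heavy atoms (8 carbon, 2 nitrogen; one six-membered non-aromatic ring with 1 hetero atom, one six-membered aromatic ring with 1 hetero atom) in place of a group of 10 heavy atoms (9 carbon, 1 nitrogen; one six-membered non-aromatic ring with 1 hetero atom, one six-membered aromatic ring of carbon only), on a carbonyl carbon. For the measured compounds named here, no measured step trades a six-membered aromatic ring of carbon only for one with a hetero atom, so nothing measured bears directly on this change; the only guide is that the single step seen moved no further than the scatter floor and that compound 2 sits near the limit. The expectation for this assay is therefore a step of no more than the scatter, a 1.2-fold higher number from compound 2 to compound 3 (0.08 log units; within the scatter), with a real chance that compound 3 again returns only a limit. Compound 3 is estimated at 35000 nM, between 15000 nM and 80000 nM.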

Compound 3, half-maximal effective concentration: > 40000 nM
Compound 3: no number, only a limit; the forecaster's own chance of this, stated with the estimate: 50%; middle value at least 1.1-fold (0.05 log units) from the limit.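

In this assay, replacing the 1,2,3,4-tetrahydroisoquinolin-2-yl group on the carbonyl carbon with its analogue bearing a hetero atom in the six-membered aromatic ring gives an at least 1.3-fold higher number from compound 2 to compound 3 (0.13 log units; that floor lies within the scatter). From the compounds shown here alone, this adds a first probe of the aromatic ring of this group, but the printed floor does not separate the change from the scatter, and its true size stays open. The step from compound 1 to compound 3 cannot be read, because both of its ends are limits, and limits now make up most of the values at this position: the limit of > 40000 nM in this assay, at which 2 of the 3 values shown sit.

Compound 2 remains the only compound here with a number, so the compounds shown leave open whether any group on this carbonyl carbon can give a number clearly apart from the scatter in this assay. Also open, going by these compounds, is how a carboxylic acid on the aromatic ring, or an open-chain diethylamino group in place of the whole ring system, would read out, and whether changes elsewhere on the shared core would matter more than those at this position.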